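A few compounds are considered here, and "the series" means these few. Any claim that something is new, unique, unknown or untested is made for them only; others in the source may bear on it.

Measured so far in a functional assay on HEL cells (Homo sapiens) for inhibition; on this read-out higher numbers stand for weaker inhibition and lower numbers for stronger inhibition:
- Compound 1 `CC(C)c1cc(-c2n[nH]c(=O)n2-c2cccc(C(=O)NCCCC(=O)NO)c2)c(O)cc1O`: 4600 nM
- Compound 2 `CC(C)c1cc(-c2n[nH]c(=O)n2-c2ccc(C(=O)NCCCCCCC(=O)NO)cc2)c(O)cc1O`: 4600 nM
- Compound 3 `CC(C)c1cc(-c2n[nH]c(=O)n2-c2cccc(NC(=O)CCCCC(=O)NO)c2)c(O)cc1O`: 1600 nM

Compound 2, at 4600 nM, is level with compound 1, at 4600 nM, while compound 3 has the lower number, 1600 nM. The next compound to be measured is compound 4 `CC(C)c1cc(-c2n[nH]c(=O)n2-c2ccc(C(=O)NCCCC(=O)NO)cc2)c(O)cc1O`, and the change from compound 2 is hydroxycarbamoyl in place of 3-(hydroxycarbamoyl)propyl on a saturated chain carbon, three bonds along the chain from an amide-type nitrogen. Put simply, this is hydroxycarbamoyl in place of 3-(hydroxycarbamoyl)propyl on a saturated chain carbon, three bonds along the chain from an amide-type nitrogen. Cut one bond further out, it reads 6-(hydroxycarbamoyl)hexyl to 3-(hydroxycarbamoyl)propyl.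

Among the measured compounds shown here, no measured step isolates this change. For the measured compounds named here, the only step available is a 2.9-fold lower number from compound 1 to compound 3 (0.46 log units; beyond the scatter), which is modest and replaces one whole side chain with another. Given that guide, a small change in this assay is expected, with no firm direction and probably nothing beyond the scatter. The expected size is a 1.1-fold higher number from compound 2 to compound 4 (0.04 log units; within the scatter). For compound 4 the estimated value is 5000 nM, with an expected range of 1800 nM to 14000 nM.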

Compound 4, half-maximal inhibitory concentration: 4600 nM
Estimate against measurement, compound 4: 1.1-fold (0.04 log units) above, and the stated range covers the measured number.
By their numbers in this assay, from the lowest: compound 3; then compounds 1, 2 and 4 (each within the scatter of the next).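

In this assay, shortening the chain from 6-(hydroxycarbamoyl)hexyl to 3-(hydroxycarbamoyl)propyl gives no change at the digits printed from compound 2 to compound 4 (within the scatter). This is the first pair shown that isolates chain length at this place, and for these two lengths, the read-out does not respond to the change. Nothing at hand explains why the two chains read alike.

The compounds shown leave open whether a chain of intermediate length, such as 5-(hydroxycarbamoyl)pentyl, or a longer chain than 6-(hydroxycarbamoyl)hexyl would read the same on this amide. They also leave open whether the hydroxycarbamoyl group at the chain end matters here, which a carboxylic acid in its place could test.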